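Fluoro for bromo on the aryl ring of compound 2

The source may hold more compounds than are shown below. What is called first, only, known or untested is meant among the compounds shown, and "the series" means these compounds.

Measured so far:
compound 1 `Oc1c(C(Nc2ccccc2)c2ccccc2)ccc2cccnc12` — 16%
compound 2 `O=C(O)c1ccc(NC(c2ccc(Br)cc2)c2ccc3cccnc3c2O)cc1` — 16%

In an assay on HCT-116 cells for inhibition of CAAX prenyl protease 2 (Homo sapiens), read by fluorescence, in plasma, with a stated time of 24 h, tested at 25 uM (a lower number here means less inhibition, a higher number more inhibition at the concentration tested (going by the name of the read-out)), compound 1 gives 16%, and compound 2 gives 16%. Compound 2 therefore stands level with compound 1 at the digits shown; the two values lie within the scatter of each other, and no order between them can be read from these numbers. Both sit at a low level of inhibition at the concentration tested.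

Compound 3 `O=C(O)c1ccc(NC(c2ccc(F)cc2)c2ccc3cccnc3c2O)cc1` has not yet been tested in this assay. It differs from compound 2 in one place: fluoro in place of bromo on an aromatic carbon. Going by the values given here, no measured pair shows what this change does. Among the compounds with values here, with only two compounds known and both at the same low level, nothing in the data points to a shift in either direction, so a step of no more than the scatter is expected.

For compound 3 the estimated value in this assay is 14%, with a range from 2% to 28%. For compound 3 the expected step of a number 2 percentage points lower from compound 2 to compound 3 (within the scatter) is estimated to remain within the scatter.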

Compound 3, a percentage reported as inhibition, at one concentration (the size of the read-out at that concentration, not a potency): 16%
The estimate for compound 3 lay 2 percentage points below the measured number, and the stated range covers the measured number.
By their numbers in this assay, from the lowest: compounds 1, 2 and 3 (each within the scatter of the next).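

In this first one-place pair of the series, fluoro in place of bromo gives no change at the digits printed from compound 2 to compound 3 (within the scatter) in this assay. This adds a measured step at this position to what the earlier values of the series could show. On an aromatic carbon para to a large group, the two halogens cannot be told apart in this read-out at the concentration tested, and compound 3 stays at the same low level of inhibition. No measurement available here bears on why the exchange leaves the read-out in this position.

As far as these compounds go, whether a different kind of group at this place, such as an amine, a nitrile or a methoxy group, would move the read-out remains open. Also open, from the compounds shown here alone, is whether a longer chain there would do so.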